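Chloro-to-fluoro swap on the benzylsulfanyl arm, twice over

The source may report more compounds than this note shows. Statements on the series, on what has been measured and on what is new or still open speak of the compounds shown alone.

Measured compounds in a functional assay on the whole organism (artery, strain albino) with Rattus norvegicus as the target, with a stated time of 15 min, at a dose of 10 mg/kg by the oral route; a higher number here means more inhibition at the dose given (going by the name of the read-out), a lower number less inhibition:
compound 1 `CC1=C(C(=O)Nc2ccc(F)cc2)C(c2ccc([N+](=O)[O-])cc2)N=C(SCc2ccc(Cl)cc2)N1` — 3.6%
compound 2 `CC1=C(C(=O)Nc2ccc(F)cc2)C(c2ccc([N+](=O)[O-])cc2)N=C(SCc2ccc(F)cc2)N1` — 3.1%
compound 3 `CC1=C(C(=O)Nc2ccc([N+](=O)[O-])cc2)C(c2ccc(Br)cc2)N=C(SCc2ccc(Cl)cc2)N1` — 3.1%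

Compound 1 and compound 2 share a core and differ only in the change (fluoro in place of chloro on an aromatic carbon). That change gives a number 0.5 percentage points lower from compound 1 to compound 2 (within the scatter). Compound 3 carries a different core; how it differs from compound 1 is not broken down here. In this assay compound 3 gives 3.1%, which is level with compound 2 at the digits given and sits within the scatter of compound 1.

Compound 4, `CC1=C(C(=O)Nc2ccc([N+](=O)[O-])cc2)C(c2ccc(Br)cc2)N=C(SCc2ccc(F)cc2)N1`, has not been measured. It stands to compound 3 as compound 2 stands to compound 1: the change (fluoro in place of chloro on an aromatic carbon), the same change as before, made at the same place. For the measured compounds named here, since the one measured instance of this change produced only a number 0.5 percentage points lower from compound 1 to compound 2 (within the scatter), and since all three measured numbers lie close together, the step from compound 3 to compound 4 is expected to be about a number 0.1 percentage points lower from compound 3 to compound 4 (within the scatter). Compound 4 is therefore estimated at 3%, with a likely range from 0% to 10%.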

Compound 4, a percentage reported as inhibition, in the whole organism at one dose (the size of the read-out at that dose, not a potency): 2.6%
The estimate for compound 4 lay 0.4 percentage points above the measured number; the range from low to high includes it.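

In this assay, going from (4-chlorobenzyl)sulfanyl to (4-fluorobenzyl)sulfanyl on the second core gives a number 0.5 percentage points lower from compound 3 to compound 4 (within the scatter). Set beside the earlier instance, the change reads alike on both cores: the same change on two cores in this assay, a number 0.5 percentage points lower (within the scatter) from compound 1 to compound 2 and a number 0.5 percentage points lower (within the scatter) from compound 3 to compound 4, 0 percentage points apart, within the scatter of two such steps. This shows that the swap behaves no differently on the core of compound 3 than on the core of compound 1, but it does not show that the swap has any effect of its own, as neither step stands clear of the scatter and a match between two steps this small says little about how well the change carries over to a compound with a larger read-out.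

The compounds shown hold only chloro and fluoro in this place, so it remains open how an amine, a carboxylic acid or a longer alkyl chain there would read in this assay. As far as these compounds go, whether the same match would hold on a third core also remains open, as does how these compounds would compare at any other dose.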